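The compounds below may be only part of what the source reports. "The series", "measured", "known", "first", "only" and "open" are said of these compounds alone.

Compound 1 `CCc1cccc2c(O)c(-c3occ(C)c3C(=O)O)ccc12`: 0.3 ug/mL
Compound 2 `CCOC(=O)c1c(C)coc1-c1ccc2c(CC)cccc2c1OC`: 3.9 ug/mL

Both values come from a functional assay on MDA-MB-231 cells (Homo sapiens) for cytotoxicity, read by MTT assay, with a stated time of 72 h; a lower number here means that less compound is needed, a higher number that more compound is needed for the effect. Of the two, compound 2 holds the higher number at 3.9 ug/mL, and compound 1 gives 0.3 ug/mL. The gap between these two values lies beyond the scatter. Compound 3 `CCc1cccc2c(OC)c(-c3occ(C)c3C(=S)OC)ccc12` departs from compound 2 by one exchange on the shared core: a group of 4 heavy atoms (2 carbon, 1 oxygen, 1 sulfur; no ring) in place of a group of 5 heavy atoms (3 carbon, 2 oxygen; no ring), on an aromatic carbon. Going by the values given here, no measured pair isolates this kind of exchange, so the expectation in this assay is for no change beyond the scatter, in either direction. The expected step runs a 1.3-fold lower number from compound 2 to compound 3 (0.11 log units; within the scatter). For compound 3 the estimated value is 3 ug/mL, with an expected range of 1 ug/mL to 10 ug/mL.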

Compound 3, concentration for half-maximal effect: 5.8 ug/mL
Estimate against measurement, compound 3: 1.9-fold (0.29 log units) below; measured number inside the range.
By their numbers in this assay, from the lowest: compound 1; then compounds 2 and 3 (each within the scatter of the next).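

In this assay, the exchange of ethoxycarbonyl for the sulfur-bearing group of 4 heavy atoms, on an aromatic carbon of the five-membered aromatic ring with 1 oxygen, gives a 1.5-fold higher number from compound 2 to compound 3 (0.17 log units; within the scatter). Going by these compounds alone, this is the first one-place reading at this position, and it does not separate the two groups, so this exchange leaves the read-out level here. No supporting data are available to explain this result.

As far as these compounds go, whether a primary amide or a longer ester chain at this position would stay level with these two groups remains open. A single exchange also cannot show how far this tolerance extends across other groups at this position.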